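Ethynyl for thiophenyl on a nucleoside scaffold: an expected gain

The source may report more compounds than this note shows. Statements on the series, on what has been measured and on what is new or still open speak of the compounds shown alone.

Three nucleoside analogues have been tested in a functional assay on CEM-DNR-bulk cells (Homo sapiens), read by MTT assay, with a stated time of 72 h; a higher number here means a weaker inhibitor, a lower number a stronger inhibitor. Compound 1 `C#Cc1cn([C@@H]2O[C@H](CO)[C@@H](O)[C@H]2O)c2ncnc(C)c12` gives 160 nM in this assay. Compound 3 `Cc1ncnc2c1c(-c1cccs1)cn2[C@@H]1O[C@H](CO)[C@@H](O)[C@H]1O` reaches only the limit of this assay, > 20000 nM, which is not a number. Compound 2 `COc1nc(N)nc2c1c(-c1cccs1)cn2[C@@H]1O[C@H](CO)[C@@H](O)[C@H]1O` likewise stops at the limit of this assay, > 20000 nM. The difference between compound 3 and compound 1 is ethynyl in place of thiophen-2-yl on an aromatic carbon, and this change produced an at least 120-fold lower number from compound 3 to compound 1 (2.09 log units; beyond the scatter). Two of the three results sit at the limit of > 20000 nM in this assay, at which 2 of the 3 values shown sit, so the true size of that step is not fully known.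

Compound 4 `C#Cc1cn([C@@H]2O[C@H](CO)[C@@H](O)[C@H]2O)c2nc(N)nc(OC)c12` has not been measured. It differs from compound 2 by ethynyl in place of thiophen-2-yl on an aromatic carbon, the same change as from compound 3 to compound 1, made on a different core; the difference between the two cores is not broken down here. Compound 4 is expected to show a step of an at least 13-fold lower number from compound 2 to compound 4 (1.12 log units; beyond the scatter) in this assay, resting on the step from compound 3 to compound 1 of an at least 120-fold lower number from compound 3 to compound 1 (2.09 log units; beyond the scatter). Compound 4 is therefore estimated at 1500 nM, between 150 nM and 20000 nM.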

Compound 4, half-maximal inhibitory concentration: > 20000 nM
Compound 4: no number, only a limit; the forecaster's own chance of this, stated with the estimate: 35%; middle value at least 13-fold (1.12 log units) from the limit.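

Compound 2 and compound 4 both stop at a limit of this assay rather than giving a number, so no step can be read between them: the limit of > 20000 nM in this assay, at which 3 of the 4 values shown sit. The compounds shown leave open whether ethynyl in place of thiophen-2-yl changes the number at all on the core shared by compound 2 and compound 4.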